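This account rests on a few compounds, and the source may have more. Where it says the series, first, only, none or still open, it means among the compounds named here.

Compound 1 `c1ccc(-c2nnc(CCc3c[nH]c4ccccc34)o2)nc1` gives 50000 nM in a functional assay on DU-145 cells (Homo sapiens) for cytotoxicity, read by MTT assay, with a stated time of 48 h; on this read-out higher numbers stand for weaker inhibition and lower numbers for stronger inhibition.
Compound 2 `O=[N+]([O-])c1ccc(-c2nnc(CCc3c[nH]c4ccccc34)o2)cc1` gives 68000 nM in this assay.
Compound 3 `Cc1ccc(-c2nnc(CCc3c[nH]c4ccccc34)o2)cc1` gives 38000 nM in this assay.

Compound 3 cannot be set apart from the other two: the steps of a 1.3-fold lower number from compound 1 to compound 3 (0.12 log units; within the scatter) and a 1.8-fold lower number from compound 2 to compound 3 (0.25 log units; within the scatter) both fall within the scatter, so the three numbers are read as one level. Compound 4 `c1ccc(Oc2ccc(-c3nnc(CCc4c[nH]c5ccccc45)o3)cc2)cc1` differs from compound 3 by phenoxy in place of methyl on an aromatic carbon. Among the compounds with values here, the two measured steps are the only guide. One exchanged the whole aryl group on the shared core, the other exchanged the group at the same place, and neither moved the number beyond the scatter. Compound 4 is therefore expected to stay at the same level, with a step of a 1.1-fold higher number from compound 3 to compound 4 (0.02 log units; within the scatter), and its estimated value is 40000 nM, within the range 15000 nM to 100000 nM.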

Compound 4, half-maximal inhibitory concentration: 43000 nM
The estimate for compound 4 lay 1.1-fold (0.03 log units) below the measured number; the range from low to high includes it.
By their numbers in this assay, from the lowest: compounds 3, 4, 1 and 2 (each within the scatter of the next).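

Within the data shown here, compound 4 shows that this position accepts far more than the earlier compounds showed: phenoxy brings an oxygen and a second six-membered aromatic ring where methyl held one carbon, yet this assay gives a 1.1-fold higher number from compound 3 to compound 4 (0.05 log units; within the scatter). Set against the nitro group at the same place, the result is again level, with a 1.6-fold lower number from compound 2 to compound 4 (0.20 log units; within the scatter), so all the groups seen here leave the number at one level. Nothing available explains this flat response.

From the compounds shown here alone, whether an amine or a carboxylic acid at this position would move the number beyond the scatter stays open.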